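A few compounds are considered here, and "the series" means these few. Any claim that something is new, unique, unknown or untested is made for them only; others in the source may bear on it.

Measured in an ADME assay on a cell-free system (plasma, Mus musculus, strain CD-1) for metabolic stability, read by LC-MS, tested at 1 uM; on this read-out lower numbers stand for a shorter-lived compound and higher numbers for a longer-lived compound:
Compound 1 `Cn1nc(-c2ccc(NC(=O)CCc3nc4ccccc4c(=O)[nH]3)cc2)c2ccccc21`: > 16.6 h
Compound 2 `COc1ccccc1NC(=O)[C@H]1CC[C@@H](NC(=O)CCc2nc3ccccc3c(=O)[nH]2)CC1`: > 16.6 h
Compound 3 `COc1ccccc1N(C)C(=O)c1ccc(NC(=O)CCc2nc3ccccc3c(=O)[nH]2)cc1`: 0.633 h

Compound 1 stands at a limit of the measurement rather than at a true number: > 16.6 h. Compound 2 shares that limit, giving (the limit of > 16.6 h in this assay, at which 2 of the 3 values shown sit). Compound 3 goes against this pattern with a measured 0.633 h.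

Compound 4 `Cn1c(-c2ccc(NC(=O)CCc3nc4ccccc4c(=O)[nH]3)cc2)nc2ccccc21` has the same atoms as compound 1, joined differently: 1-methyl-1H-benzimidazol-2-yl in place of 1-methyl-1H-indazol-3-yl on an aromatic carbon. In words, 1-methyl-1H-benzimidazol-2-yl replaces 1-methyl-1H-indazol-3-yl on an aromatic carbon, para to a large group. Among the measured compounds shown here, no two measured compounds differ in just one place, so no measured step can serve as a guide. No step beyond the usual scatter is expected in this assay, and this expectation rests on compound 1 with its limit of > 16.6 h. The range still reaches lower, as compound 3 shows a short half-life of 0.633 h. The expected change is a step that the limit leaves unreadable from compound 1 to compound 4. For compound 4, the estimate is 17 h. The expected range runs from 5 h to 50 h.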

Compound 4, half-life: > 8.33 h
Compound 4 ended at the assay's limit; the forecaster's own chance of this, stated with the estimate: 60%; the middle value is on the limit's open side.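

Among the compounds shown here, compound 1 and compound 4 both give limits rather than true numbers, and no step between them can be read. From the compounds shown here alone, whether 1-methyl-1H-benzimidazol-2-yl in place of 1-methyl-1H-indazol-3-yl changes the half-life in this assay stays open, as do the true half-lives of both compounds.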